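The source may hold more compounds than are shown below. What is called first, only, known or untested is meant among the compounds shown, and "the series" means these compounds.

Measured so far in a functional assay on SGC-7901 cells (Homo sapiens) for inhibition, read by MTT assay, with a stated time of 72 h; a lower number here means a stronger inhibitor, a higher number a weaker inhibitor:
- Compound 1 `Cc1ccc(N2CCCC2)c(C(=O)Nc2ccc(CNC(=O)OCc3cccnc3)cc2)c1`: 65300 nM
- Compound 2 `O=C(NCc1ccc(NC(=O)c2cccc(F)c2N2CCCC2)cc1)OCc1cccnc1`: > 100000 nM

Among the compounds with values here, compound 1, at 65300 nM, holds the only true number in this assay so far. Compound 2 gives > 100000 nM, which is a limit of the assay and not a number. That leaves the limit of > 100000 nM in this assay, at which 1 of the 2 values shown sits, as the other point of reference, so there is little to place compound 1 against.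

The next compound is compound 3 `O=C(NCc1ccc(NC(=O)c2cc(F)ccc2N2CCCC2)cc1)OCc1cccnc1`. It has fluoro in place of methyl on an aromatic carbon, para to a pyrrolidin-1-yl group (fluoro in place of methyl on an aromatic carbon). Within the data shown here, no pair of measured compounds shows what a single swap of this kind does in this assay, so any forecast is cautious. Compound 2 also carries a fluoro group, and its > 100000 nM gives a slight lean towards weaker inhibition. The expected change is small, a 1.1-fold higher number from compound 1 to compound 3 (0.06 log units; within the scatter), and is not expected to go beyond the usual scatter of repeat measurements. For compound 3 the estimate is 75000 nM, with an expected range from 35000 nM to 100000 nM.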

Compound 3, half-maximal inhibitory concentration: 44800 nM
Estimate against measurement, compound 3: 1.7-fold (0.22 log units) above; measured number inside the range.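

In this assay, the series now has its first single change that can be read: fluoro in place of methyl on an aromatic carbon, para to a pyrrolidin-1-yl group, gives a 1.5-fold lower number from compound 1 to compound 3 (0.16 log units; within the scatter). At this position, then, the swap leaves compound 3 indistinguishable from compound 1 in this assay, and the presence of a fluoro group on this ring does not by itself bring a compound to the limit of the assay. Compound 2, the other fluoro compound, still gives a limit and not a number, so it offers no size of effect to set beside this step: the limit of > 100000 nM in this assay, at which 1 of the 3 values shown sits.

Only methyl and fluoro stand at this position in the compounds shown, so it remains open whether a different group there, such as a methoxy group, a nitrile or an amine, would move the number beyond the usual scatter. This single pair also leaves open whether the same swap would give a similar result on a core other than that of compound 1.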